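The compounds below may be only part of what the source reports. "The series", "measured", "known", "first", "only" and "open" are said of these compounds alone.

Compound 1 `Cc1cc(C(=O)Nc2c(F)cccc2F)nn1Cc1cc(Cl)ccc1OCc1ccccc1` is the reference point here. In an assay on CHO-K1 cells for displacement of a labelled ligand from prostaglandin E2 receptor EP1 subtype (Homo sapiens) (a lower number here means a stronger inhibitor, a higher number a weaker inhibitor), compound 1 gives 10 nM, the lowest of the three numbers measured. Compound 3 `Cc1cc(NC(=O)C2CCCC2)nn1Cc1cc(Cl)ccc1OCC(C)C` comes closest: in this assay compound 3 gives 25.1 nM. Compound 2 `CC(=O)Nc1cc(C)n(Cc2cc(Cl)ccc2OCc2ccccc2)n1` stands furthest away, and in this assay compound 2 gives 316 nM.

Compound 4 `Cc1cc(NC(=O)OCc2ccccc2)nn1Cc1cc(Cl)ccc1OCc1ccccc1` has not been measured yet. It is made from compound 1 by a single change: (benzyloxycarbonyl)amino in place of (2,6-difluorophenyl)carbamoyl on an aromatic carbon. Within the data shown here, the one measured step that touches the same place is the one to compound 2, where the (2,6-difluorophenyl)carbamoyl was cut down to acetamido and the number rose a 32-fold higher number from compound 1 to compound 2 (1.50 log units; beyond the scatter). That step shows how much the large group at this place matters when it is removed altogether. In compound 4 the group is not removed but exchanged for another one of the same size, keeping one six-membered aromatic ring and the hydrogen-bond donor, so a far smaller shift is expected. The estimate is that compound 4 gives 30 nM in this assay, within a range of 10 nM to 100 nM. This would be a step of a 3.0-fold higher number from compound 1 to compound 4 (0.48 log units; beyond the scatter), expected to be a mild weakening rather than the large loss seen with compound 2.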

Compound 4, half-maximal inhibitory concentration: 79.4 nM
Estimate against measurement, compound 4: 2.6-fold (0.42 log units) below; the measured number falls inside the stated range.
By their numbers in this assay, from the lowest: compound 1; then compound 3; then compound 4; then compound 2.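

Matching size does not preserve the number at this position: (benzyloxycarbonyl)amino and (2,6-difluorophenyl)carbamoyl have the same heavy-atom count, one six-membered aromatic ring and one hydrogen-bond donor, yet in this assay the exchange gives a 7.9-fold higher number from compound 1 to compound 4 (0.90 log units; beyond the scatter), so these shared counts alone do not set the result. Compound 4 also shows that the far end of the group matters when the nitrogen stays attached to the ring, since benzyloxy in place of the methyl of compound 2 gives a 4.0-fold lower number from compound 2 to compound 4 (0.60 log units; beyond the scatter) and so recovers part, but not all, of the ground between compound 2 and compound 1. No supporting measurement is available to explain either step.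

As far as these compounds go, the step from compound 1 to compound 4 changes several things at once: the two fluorines leave, an oxygen enters, and the group is joined to the ring through nitrogen rather than through the carbonyl carbon, so their separate shares stay unknown. A phenylcarbamoyl group without fluorine, or a phenylacetamido group with a carbon in place of the carbamate oxygen, would help to separate them.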